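Ester in Place of Aryl Amide on the Shared Core

This account rests on a few compounds, and the source may have more. Where it says the series, first, only, none or still open, it means among the compounds named here.

Compound 2 `CCn1c(C(=O)Nc2ccc(OC(F)(F)F)cc2)ccc1C(CC)(CC)c1ccc(OCC(=O)C(C)(C)C)c(C)c1` stands in an assay on HL-60 cells for agonist activity at vitamin D3 receptor (Homo sapiens), read by microscopy, with a stated time of 96 h (on this read-out higher numbers stand for an effect only at larger amounts of compound and lower numbers for an effect already at smaller amounts), only at a limit, > 50000 nM, with no number behind it (the limit of > 50000 nM in this assay, at which 1 of the 2 values shown sits). Compound 1 `CCn1c(C(=O)N(CCC#N)CCC#N)ccc1C(CC)(CC)c1ccc(OCC(=O)C(C)(C)C)c(C)c1` gives 870 nM in this assay. Among the measured compounds shown here, the one measured step, an at least 57-fold higher number from compound 1 to compound 2 (1.75 log units; beyond the scatter), is the only guide here. Compound 3 `CCn1c(C(=O)OCc2ccccn2)ccc1C(CC)(CC)c1ccc(OCC(=O)C(C)(C)C)c(C)c1` carries (pyridin-2-yl)methoxy in place of (4-(trifluoromethoxy)phenyl)amino on a carbonyl carbon. That change is not covered by any measured pair, so a return part of the way toward compound 1 is expected, not a full one. For compound 3 the estimated step is an at least 8.3-fold lower number from compound 2 to compound 3 (0.92 log units; beyond the scatter). Compound 3 is therefore expected near 6000 nM, within a range of 600 nM to 50000 nM.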

Compound 3, half-maximal effective concentration: > 50000 nM
Compound 3 was reported as a limit; the forecaster's own chance of this, stated with the estimate: 30%; at least 8.3-fold (0.92 log units) between middle value and limit.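

In this assay, replacing the group on the carbonyl carbon of compound 1 with (pyridin-2-yl)methoxy gives an at least 57-fold higher number from compound 1 to compound 3 (1.75 log units; beyond the scatter). Of the three compounds shown, only compound 1, whose group has no ring, gives a number, while the two groups with a six-membered aromatic ring, one joined through nitrogen and one through oxygen, both end at a limit. The step between compound 2 and compound 3 cannot be read, since each is reported only as a limit: the limit of > 50000 nM in this assay, at which 2 of the 3 values shown sit.

Going by these compounds, whether a ring is what separates these groups stays open. A carboxylic acid, an ethyl ester or a diethylamide on the same carbonyl carbon would bear on this.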